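Exposure of a Bicyclic Amine Variant on a Shared Core

The source may report more compounds than this note shows. Statements on the series, on what has been measured and on what is new or still open speak of the compounds shown alone.

Among the measured compounds shown here, compound 1 `CCOC(=O)N1CCN(Cc2cc(Nc3nc(C)cn4c(-c5cn[nH]c5)cnc34)sn2)CC1` is the only member of this small set with a number in an ADME assay on the whole organism (plasma) for pharmacokinetics, with Rattus norvegicus as the target, with a stated time of 6 h, at a dose of 10 mg/kg by the oral route; a higher number here means more compound in the circulation at the dose given, a lower number less compound in the circulation. In this assay compound 1 gives 178 ng.h/mL. Two close relatives were examined but returned no number. In this assay compound 2 `CC(=O)N1CCN(Cc2cc(Nc3nc(C)cn4c(-c5cn[nH]c5)cnc34)sn2)CC1` gives "not determined" (no result reported). In this assay compound 3 `Cc1cn2c(-c3cn[nH]c3)cnc2c(Nc2cc(CN3CCN(C)C(=O)C3)ns2)n1` gives "not determined" (no result reported). For the measured compounds named here, compound 1 therefore stands alone and no comparison between measured compounds can be drawn.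

Going by the values given here, compound 4 `Cc1cn2c(-c3cn[nH]c3)cnc2c(Nc2cc(CN3C[C@H]4CC[C@@H](C3)O4)ns2)n1` keeps the shared core of compound 1 and changes only one group: a group of 8 heavy atoms (6 carbon, 1 nitrogen, 1 oxygen; one five-membered non-aromatic ring with 1 hetero atom, one six-membered non-aromatic ring with 2 hetero atoms) in place of a group of 11 heavy atoms (7 carbon, 2 nitrogen, 2 oxygen; one six-membered non-aromatic ring with 2 hetero atoms), on a saturated chain carbon bound to an aromatic carbon. The group that leaves is the 4-(ethoxycarbonyl)piperazin-1-yl; the group that enters has no common name and carries two defined stereocentres. Both sit on a saturated chain carbon bound to an aromatic carbon.

Among the compounds with values here, no step between measured compounds exists here, so the size and direction of the change can only be expected, not read off. The step of a 1.1-fold higher number from compound 1 to compound 4 (0.05 log units; within the scatter) is expected to stay within the usual scatter of this assay, with no clear direction. Compound 4 is therefore expected to give 200 ng.h/mL in this assay, with a range from 60 ng.h/mL to 650 ng.h/mL.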

Compound 4, area under the concentration-time curve: 169 ng.h/mL
Compound 4: the middle estimate sits 1.2-fold (0.07 log units) above what was measured; the measured number falls inside the stated range.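

Among the compounds shown here, with a second number in this assay, a first comparison on the shared core can now be read as a 1.1-fold lower number from compound 1 to compound 4 (0.02 log units; within the scatter) and it is the only step available at this place. On a saturated chain carbon bound to an aromatic carbon, a group of 8 heavy atoms with two non-aromatic rings and 2 defined stereocentres can stand in for the 4-(ethoxycarbonyl)piperazin-1-yl of 11 heavy atoms, with no difference that this read-out separates from the usual scatter of repeated measurements. Nothing measured here bears on the reason for this result.

Compound 2 and compound 3 have no number, so steps involving them cannot be read, and their acetyl and lactam-bearing groups add nothing to the comparison. From the compounds shown here alone, one exchange also cannot show whether the result would hold for very different groups at the same place, such as a simple primary amine or a carboxylic acid, so the range of groups tolerated here remains open.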